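Two Hydroxyls Where One Stood: A Planned Next Step

A few compounds are considered here, and "the series" means these few. Any claim that something is new, unique, unknown or untested is made for them only; others in the source may bear on it.

Measured so far:
Compound 1, `C[C@@H](O)CCn1nc2c(Br)c(Br)c(Br)c(Br)c2n1`: 24%
Compound 2, `OC(CCn1nc2c(Br)c(Br)c(Br)c(Br)c2n1)c1ccccc1`: 0%

Both compounds were tested in a functional assay on CCRF-CEM cells (Homo sapiens) for antiproliferative activity, read by MTT assay, with a stated time of 48 h, tested at 100 uM; a higher number here means a weaker effect of the compound at the concentration tested, a lower number a stronger effect. Compound 1 gives 24%, while compound 2 gives 0%. Of the two numbers, compound 1 is the higher, and the gap to compound 2 lies beyond the usual scatter, so compound 1 shows the weaker effect of the pair. The two differ in more than one place, so nothing can be said about which part of the difference matters.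

Compound 3, `OCC(O)Cn1nc2c(Br)c(Br)c(Br)c(Br)c2n1`, has not yet been measured. It differs from compound 1 in one place: 1,2-dihydroxyethyl in place of 2-hydroxypropyl on a saturated chain carbon bound to an aromatic nitrogen. Within the data shown here, no step between measured compounds tests this kind of change, so the expectation rests on compound 1 alone. The estimated step of a number 6 percentage points higher from compound 1 to compound 3 (within the scatter) is small, within the scatter, leaning towards a slightly higher number. Compound 3 is expected to give about 30%, within 5% to 60%.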

Compound 3, a percentage reported as activity, at one concentration (the size of the read-out at that concentration, not a potency): 1%
Estimate against measurement, compound 3: 29 percentage points above, and the stated range ends above it.
By their numbers in this assay, from the lowest: compounds 2 and 3 (each within the scatter of the next); then compound 1.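

In this assay, putting 1,2-dihydroxyethyl in place of 2-hydroxypropyl on a saturated chain carbon bound to an aromatic nitrogen gives a number 23 percentage points lower from compound 1 to compound 3 (beyond the scatter) and so a stronger effect at the concentration tested. This shows that the read-out responds to a single change at this place, even though both groups hold 4 heavy atoms and no ring. The change adds a hydrogen-bond donor and acceptor and removes a defined stereocentre, but no available measurement explains the step.

Among these compounds, the single step cannot separate these differences, so it remains open which of them matters. On these data alone, it also remains open whether an amine, a carboxylic acid or a longer chain at this place would give a number like that of compound 3 in this assay or one like that of compound 1.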